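The source may hold more compounds than are shown below. What is called first, only, known or untested is meant among the compounds shown, and "the series" means these compounds.

Working notes on the series.

Compound 1 `CS(=O)(=O)c1ccc(C2=NN(c3ccc(S(N)(=O)=O)cc3)C(c3ccc(F)cc3)C2)cc1` gives 65.7% in a functional assay on the whole organism for inhibition, with Rattus norvegicus as the target, read by paw edema, with a stated time of 3 h, at a dose of 50 mg/kg by the oral route (on this read-out lower numbers stand for less inhibition and higher numbers for more inhibition at the one dose given (going by the name of the read-out)), the highest of the three numbers in hand. Compound 2 `COc1cccc(C2CC(c3ccc(S(C)(=O)=O)cc3)=NN2c2ccc(S(N)(=O)=O)cc2)c1` gives 38.3%. Compound 3 `COc1ccc(C2CC(c3ccc(S(C)(=O)=O)cc3)=NN2c2ccc(S(N)(=O)=O)cc2)cc1` gives 42.4% in this assay; it stands second highest of the three, within the scatter of compound 2 and well apart from compound 1, the step being a number 23.3 percentage points lower from compound 1 to compound 3 (beyond the scatter).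

The next compound is compound 4 `COc1cc(C2CC(c3ccc(S(C)(=O)=O)cc3)=NN2c2ccc(S(N)(=O)=O)cc2)cc(OC)c1OC`, which differs from compound 3 in one place: 3,4,5-trimethoxyphenyl in place of 4-methoxyphenyl on a saturated ring carbon.

For the measured compounds named here, two measured steps bear on this change, since both replace a fluorine-bearing aryl group with a methoxy-bearing one: a number 27.4 percentage points lower from compound 1 to compound 2 (beyond the scatter) and a number 23.3 percentage points lower from compound 1 to compound 3 (beyond the scatter). Moving the single methoxy group between ring positions made no difference beyond the scatter, a number 4.1 percentage points higher from compound 2 to compound 3 (within the scatter). Adding two further methoxy groups has no direct precedent here. The two relevant steps both point downward when methoxy enters, so a further small fall, or no step beyond the scatter, is the likely outcome; the expected step is a number 7.4 percentage points lower from compound 3 to compound 4 (within the scatter).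

Compound 4 is therefore estimated to give 35% in this assay, in the range 15% to 55%.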

Compound 4, a percentage reported as inhibition, in the whole organism at one dose (the size of the read-out at that dose, not a potency): 73.7%
The estimate for compound 4 lay 38.7 percentage points below the measured number; measured number above the stated range.
By their numbers in this assay, from the lowest: compounds 2 and 3 (each within the scatter of the next); then compounds 1 and 4 (each within the scatter of the next).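

In this assay, methoxy groups on the aryl ring at this saturated ring carbon do not simply lower the number: 3,4,5-trimethoxyphenyl in place of 4-methoxyphenyl gives a number 31.3 percentage points higher from compound 3 to compound 4 (beyond the scatter), and in place of 3-methoxyphenyl it gives a number 35.4 percentage points higher from compound 2 to compound 4 (beyond the scatter), so the two compounds with a single methoxy group do not foretell the one with three. Set against 4-fluorophenyl, the same group gives a number 8 percentage points higher from compound 1 to compound 4 (within the scatter), which shows that the fall seen with a single methoxy group does not extend to every methoxy-bearing aryl group at this position. Nothing in hand accounts for the rise, and the series gives no explanation for it.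

Whether the rise needs all three methoxy groups, or a particular pair of them, stays open, as the compounds shown hold only one or three. Also open, going by these compounds, is how an ethoxy group, a longer alkoxy chain or a dimethylamino group on this aryl ring would read, and whether the numbers keep this order at other doses, as each one here stands at a single dose.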